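This account rests on a few compounds, and the source may have more. Where it says the series, first, only, none or still open, it means among the compounds named here.

Compound 1 `CCCCCCCCCCCCCCc1nc(N2CCC2)nc(OC2CCC2)c1O` gives 105% in a functional assay on cells (Lymphocyte, Homo sapiens), read by a luciferase reporter and ATP content, with a stated time of 48 h, tested at 1 uM; on this read-out lower numbers stand for a stronger effect and higher numbers for a weaker effect at the one concentration tested.
Compound 2 `Cc1nc(OC2CCC2)nc(N2CCC2)c1O` gives 101% in this assay.
Compound 3 `CCCCCCCCCCCCCCc1nc(OC2CCC2)nc(OC2CCC2)c1O` gives 99% in this assay.

All three measured compounds sit close together in this assay. The step of a number 6 percentage points higher from compound 3 to compound 1 (within the scatter) is made by azetidin-1-yl in place of cyclobutyloxy on an aromatic carbon. Compound 4 `Cc1nc(N2CCC2)nc(N2CCC2)c1O` is not yet measured; it differs from compound 2 by azetidin-1-yl in place of cyclobutyloxy on an aromatic carbon. This is the same kind of change as from compound 3 to compound 1, though the surroundings differ: in compound 4 the place is meta to a methyl group and meta to an azetidin-1-yl group, whereas in compound 1 it is meta to a cyclobutyloxy group and meta to a large group. How the cores of compound 2 and compound 3 differ is not broken down here. A step of about a number 2 percentage points higher from compound 2 to compound 4 (within the scatter) is expected from compound 2 to compound 4 in this assay, because a number 6 percentage points higher from compound 3 to compound 1 (within the scatter) stayed within the scatter. Compound 4 is therefore estimated at 103%, between 90% and 116%.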

Compound 4, a percentage reported as activity, at one concentration (the size of the read-out at that concentration, not a potency): 101%
Compound 4: the middle estimate sits 2 percentage points above what was measured; the range from low to high includes it.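

Putting azetidin-1-yl in place of cyclobutyloxy on an aromatic carbon gives no change at the digits printed from compound 2 to compound 4 (within the scatter) in this assay. The two cores give the same answer as far as this read-out can tell: the same change on two cores in this assay, a number 6 percentage points higher (within the scatter) from compound 3 to compound 1 and no change at the digits printed (within the scatter) from compound 2 to compound 4, 6 percentage points apart, within the scatter of two such steps. Among these compounds, neither step leaves the scatter, so this shows only that the swap moved the read-out on neither core; it does not show that the swap would stay silent in a compound with a clear effect, or at another concentration.

The compounds shown leave open whether a different group at this place, such as a carboxylic acid or an open-chain amine, would move the read-out. They also leave open whether any such group would act alike on both cores.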